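Methoxy in place of hydroxy on compound 1

A few compounds are considered here, and "the series" means these few. Any claim that something is new, unique, unknown or untested is made for them only; others in the source may bear on it.

In an ADME assay on cells (Peritoneal macrophage, Mus musculus, strain Swiss) for cytotoxicity, with a stated time of 24 h (a lower number here means that less compound is tolerated, a higher number that more compound is tolerated), compound 1 (`O=C1C=CC(=O)c2c1ccc(I)c2O`) gives > 100000 nM, which is a limit. Compound 2 (`O=C1C=CC(=O)c2c(O)c(I)cc(I)c21`) gives > 100000 nM, also a limit. Compound 1 therefore stands at the limit of > 100000 nM in this assay, at which 2 of the 3 values shown sit. Iodo in place of hydrogen on an aromatic carbon gives a step that the two limits leave unreadable from compound 1 to compound 2, so that step offers no size to carry over.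

Compound 4 (`COc1c(I)ccc2c1C(=O)C=CC2=O`) differs from compound 1 by methyl in place of hydrogen on an oxygen on an aromatic ring, hydroxy to methoxy. No readable step covers this change. Within the data shown here, the only measured methoxy compound, compound 3 (`COc1ccc(I)c2c1C(=O)C=CC2=O`), gives 13600 nM, a true number, so less tolerance is expected in this assay. The expected step is an at least 5.5-fold lower number from compound 1 to compound 4 (0.74 log units; beyond the scatter), towards less compound tolerated. For compound 4 the estimated value is 18000 nM, with an expected range of 6000 nM to 60000 nM.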

Compound 4, concentration lethal to 50% of the cells: 13300 nM
Beside the measured number, compound 4's estimate is 1.4-fold (0.13 log units) above it; measured number inside the range.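

Methyl in place of hydrogen on an oxygen on an aromatic ring gives the first readable step from the core of compound 1 in this assay, with an at least 7.5-fold lower number from compound 1 to compound 4 (0.87 log units; beyond the scatter) on the scatter-exceeding side. This shows that the hydroxy position responds to the change, whereas the earlier iodo step gave no readable size. The true size has only a floor, since compound 1 is held at a limit: (the limit of > 100000 nM in this assay, at which 2 of the 4 values shown sit).

On these data alone, it remains open whether a longer chain on the same oxygen, such as ethoxy, or an amine in place of the hydroxy, would give a similar number. Also open, as far as these compounds go, is whether methyl on the oxygen of compound 2 would give a readable step of similar size.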